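The source may hold more compounds than are shown below. What is called first, only, known or untested is meant among the compounds shown, and "the series" means these compounds.

Compound 2 `O=C(N1CCCCC1)N1CC(c2nc(-c3cccc(Cl)c3)no2)C1` is the only one of the three measured compounds that gives a number in an assay on HEK293 cells for positive allosteric modulation of metabotropic glutamate receptor 5 (Homo sapiens), read by FLIPR (on this read-out higher numbers stand for an effect only at larger amounts of compound and lower numbers for an effect already at smaller amounts), where compound 2 reaches 370 nM. Compound 1 `Cc1cccc(-c2noc(C3CN(S(=O)(=O)c4cccc(C)c4)C3)n2)c1` gives in this assay > 10000 nM, which is a limit of the assay. Compound 3 `Cc1cccc(-c2noc(C3CN(S(=O)(=O)c4ccc(Cl)cc4)C3)n2)c1` likewise gives only a limit, > 10000 nM. The step that the two limits leave unreadable from compound 1 to compound 3 therefore cannot be read because both values sit at the limit of > 10000 nM in this assay, at which 2 of the 3 values shown sit. Compound 4 `COC1CCCN(C(=O)N2CC(c3nc(-c4cccc(Cl)c4)no3)C2)C1` differs from compound 2 by methoxy in place of hydrogen on a saturated ring carbon. Within the data shown here, no measured step touches this part of the shared core, so nothing argues for a shift beyond the usual scatter. Compound 4 is expected to give about 370 nM, within 150 nM to 900 nM, an expected step of no change at the digits printed from compound 2 to compound 4 (within the scatter).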

Compound 4, half-maximal effective concentration: > 10000 nM
Compound 4 ended at the assay's limit; the forecaster's own chance of this, stated with the estimate: 5%; middle value at least 27-fold (1.43 log units) away from the limit.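

Methoxy on this saturated ring carbon, two ring bonds from the ring nitrogen, is no silent change: this assay records an at least 27-fold higher number from compound 2 to compound 4 (1.43 log units; beyond the scatter). Among these compounds, this is the first readable step, and the earlier compounds said nothing about this ring. The value of compound 4 is a limit of the assay, so the full size of the step stays unknown: the limit of > 10000 nM in this assay, at which 3 of the 4 values shown sit.

On these data alone, it remains open whether hydroxy or a fluorine atom on the same carbon would keep a measurable value. As far as these compounds go, whether an amine there would do so is equally open.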